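Swapping a Nitrile for an Acetamide on a Bridged Core

This account rests on a few compounds, and the source may have more. Where it says the series, first, only, none or still open, it means among the compounds named here.

Of the compounds shown here, two have been measured in an assay on HEK293 cells for binding affinity to Neuronal acetylcholine receptor; alpha4/beta2 (Homo sapiens); a higher number here means a weaker inhibitor, a lower number a stronger inhibitor. Compound 1 `N#Cc1ccc2c(c1)C1CNCC2C1` gives 0.5 nM in this assay, the lowest of the two numbers, while compound 2 `Cn1cnc2cc3c(cc21)C1CNCC3C1` gives 0.75 nM; the gap between them lies within the usual scatter, so neither can be ranked above the other.

Compound 3 `CC(=O)Nc1ccc2c(c1)C1CNCC2C1` has not yet been measured. It differs from compound 1 in one place: acetamido in place of cyano on an aromatic carbon. The entering group has more heavy atoms than the one it replaces and carries a hydrogen-bond donor that the nitrile lacks. Among the compounds with values here, no measured pair here shows what such a swap does, so the direction must be judged from the structures alone.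

Given that compound 1 sits at 0.5 nM, a modest loss of affinity is expected, a 4.0-fold higher number from compound 1 to compound 3 (0.60 log units; beyond the scatter) in this assay. Compound 3 is estimated at 2 nM, with a range from 0.5 nM to 8 nM.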

Compound 3, inhibition constant: 75 nM
For compound 3 the middle estimate is 38-fold (1.57 log units) below the measured one, outside the stated range (above it).
By their numbers in this assay, from the lowest: compounds 1 and 2 (each within the scatter of the next); then compound 3.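

In this assay, exchanging cyano for acetamido on this aromatic carbon gives a 150-fold higher number from compound 1 to compound 3 (2.18 log units; beyond the scatter), so the shared core does not by itself secure high affinity: the group at this position can strongly change the result. The acetamido group has more heavy atoms than cyano and also brings a hydrogen-bond donor, and this single swap changes both features at once, so the result cannot assign the loss to either one. No independent measurement is available to explain the loss.

An amine at this carbon would test the nitrogen and its hydrogen without the carbonyl and methyl of the acetamido group, while an acetyl group would test those two parts without the amide hydrogen. Which part of the acetamido group accompanies the loss therefore remains open.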